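The source may hold more compounds than are shown below. What is called first, only, known or untested is meant among the compounds shown, and "the series" means these compounds.

Two compounds built on one shared core were tested in a functional assay on HeLa cells (Homo sapiens) for cytotoxicity, in the presence of a further agent that is not named here; on this read-out lower numbers stand for stronger inhibition and higher numbers for weaker inhibition. Compound 1 `Clc1ccc(-c2cc(-c3cccs3)nc(-c3ccccc3Cl)c2)o1` gives 18500 nM in this assay. Compound 2 `Cc1ccc(-c2cc(-c3ccc(Cl)o3)cc(-c3ccsc3)n2)o1` reaches no number in this assay but only a limit of the assay, > 50000 nM. Compound 2 therefore stands at the limit described by the limit of > 50000 nM in this assay, at which 1 of the 2 values shown sits, while compound 1 shows a number below it; since compound 2 has no value of its own, no measured step between the two can be stated, and only these two readings are shown.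

Compound 3 `Clc1ccc(-c2cc(-c3ccc(Cl)o3)cc(-c3ccsc3)n2)cc1` has not yet been measured in this assay. Compound 3 differs from compound 2 by 4-chlorophenyl in place of 5-methylfuran-2-yl on an aromatic carbon. No measured step of this kind exists among the compounds shown, so the direction and size of the step cannot be drawn from data. The expected step from compound 2 to compound 3 is stated as an at least 1.6-fold lower number from compound 2 to compound 3 (0.22 log units; that floor lies within the scatter), which is a shift no larger than the usual scatter. In this assay compound 3 is expected to give about 30000 nM, with a range from 8000 nM to 50000 nM.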

Compound 3, half-maximal inhibitory concentration: 8410 nM
Beside the measured number, compound 3's estimate is 3.6-fold (0.55 log units) above it; low and high end bracket the measured number.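

Among these compounds, compound 3 gives the first step that can be read at this position, the aromatic carbon next to the ring nitrogen: in this assay, 4-chlorophenyl in place of 5-methylfuran-2-yl brings an at least 5.9-fold lower number from compound 2 to compound 3 (0.77 log units; beyond the scatter). Among the compounds shown here, this position is therefore not indifferent to what it carries, as exchanging a five-membered aromatic ring with 1 hetero atom for a six-membered aromatic ring of carbon only moves the read-out beyond the scatter, something the earlier pair, with no measured step between them, could not show. The step is only a floor, because compound 2 has a limit of the assay and no number of its own: the limit of > 50000 nM in this assay, at which 1 of the 3 values shown sits.

Going by these compounds, whether the step goes with the chlorine of the 4-chlorophenyl group, with the six-membered ring itself or with the departure of the 5-methylfuran-2-yl group stays open, as does its true size. How a plain phenyl, an amine or a carboxylic acid at this same position would read in this assay also remains an open question.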